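Lengthening the Amine Substituent: From Isopropyl to Tert-Butyl

The source may hold more compounds than are shown below. What is called first, only, known or untested is meant among the compounds shown, and "the series" means these compounds.

Of the compounds shown here, two that share one core have been measured in an assay on membranes from liver for displacement of a labelled ligand from Sigma intracellular receptor 2 (Rattus norvegicus), read by scintillation counting, with a stated time of 120 min; on this read-out higher numbers stand for weaker inhibition and lower numbers for stronger inhibition. Compound 1 `CCN1CCN(CCC(=O)Nc2nc3c(C)cccc3s2)CC1` carries an ethyl group on the ring amine nitrogen; in this assay compound 1 gives 1200 nM. Compound 2 `Cc1cccc2sc(NC(=O)CCN3CCN(C(C)C)CC3)nc12` differs from it in a single place, a 1.5-fold higher number from compound 1 to compound 2 (0.18 log units; within the scatter). Compound 2 gives 1800 nM, the higher of the two numbers, though its gap to compound 1 lies within the scatter, so the two cannot be told apart.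

The next compound, compound 3 `Cc1cccc2sc(NC(=O)CCN3CCN(C(C)(C)C)CC3)nc12`, is not yet measured. Compared with compound 2 the change is methyl in place of hydrogen on a saturated chain carbon bound to an amine nitrogen in a ring and two saturated chain carbons. Going by the values given here, the one step already seen, from compound 1 to compound 2, is of the same kind: a hydrogen on that same chain carbon replaced by a methyl, and it moved the number only within the scatter. On that basis the step from compound 2 to compound 3 is expected to be small as well, a 1.3-fold higher number from compound 2 to compound 3 (0.12 log units; within the scatter), leaning if at all toward a higher number. Compound 3 is therefore estimated at 2400 nM, with a likely range from 1000 nM to 6000 nM.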

Compound 3, inhibition constant: 200 nM
The estimate for compound 3 lay 12-fold (1.08 log units) above the measured number, and the stated range ends above it.
By their numbers in this assay, from the lowest: compound 3; then compounds 1 and 2 (each within the scatter of the next).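

In this assay, a methyl in place of hydrogen on the saturated chain carbon bound to the ring amine nitrogen can clearly move the number: isopropyl to tert-butyl gives a 9.0-fold lower number from compound 2 to compound 3 (0.95 log units; beyond the scatter), whereas the earlier step of this kind stayed within the scatter. Across these three compounds, then, each added methyl does not have the same effect, and the overall change of tert-butyl in place of ethyl on the ring amine nitrogen gives a 6.0-fold lower number from compound 1 to compound 3 (0.78 log units; beyond the scatter), so the substituent on this nitrogen can matter in this series even though the first step gave no sign of it. No measurement available here bears on the reason for this sudden drop.

The compounds shown leave open whether other groups on this nitrogen, such as cyclopropyl, cyclohexyl or a longer chain such as n-butyl, would give numbers close to that of compound 3 or lower still. They also leave open whether tert-butyl would have a similar effect if the methyl on the shared core were replaced by a hydrogen or a chlorine.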